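A few compounds are considered here, and "the series" means these few. Any claim that something is new, unique, unknown or untested is made for them only; others in the source may bear on it.

Compound 1, `CC(C)[C@H](NC(=O)COc1cccc2ccccc12)C(=O)N[C@@H](CC(=O)O)C(=O)COc1cccc(F)c1`, and compound 2, `CC(C)[C@H](NC(=O)COc1cccc2ccccc12)C(=O)N[C@@H](CC(=O)O)C(=O)COc1c(F)cccc1F`, share a core and differ only in the group on an oxygen on a saturated carbon. In a functional assay with Homo sapiens as the target (a higher number here means a weaker inhibitor, a lower number a stronger inhibitor), compound 1 gives 12000 nM. In this assay compound 2 reaches only a limit, > 100000 nM, so that compound 2 stands at the limit of > 100000 nM in this assay, at which 1 of the 2 values shown sits, and no number is known for it. Among the measured compounds shown here, the move an at least 8.3-fold higher number from compound 1 to compound 2 (0.92 log units; beyond the scatter) is the only measured step.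

Compound 3, `CC(C)[C@H](NC(=O)COc1cccc2ccccc12)C(=O)N[C@@H](CC(=O)O)C(=O)COc1c(Cl)cccc1Cl`, differs from compound 2 by the change (2,6-dichlorophenyl in place of 2,6-difluorophenyl on an oxygen on a saturated carbon). For the measured compounds named here, no measured step covers this exchange of one halogen pair for another; the step from compound 1 to compound 2 concerns a different change and is expected to carry over only in the sense that the 2,6-substituted pattern stays. Compound 3 is therefore expected to remain weak, with an estimated step of a number no higher from compound 2 to compound 3 (the limit leaves the size open) and an estimate of 100000 nM, ranging from 30000 nM to 300000 nM, most likely reported again as a limit.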

Compound 3, half-maximal inhibitory concentration: 15300 nM
Compound 3: the middle estimate sits 6.5-fold (0.82 log units) above what was measured; measured number outside the range, below it.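

In this assay, the exchange of halogens on this oxygen-linked ring gives an at least 6.5-fold lower number from compound 2 to compound 3 (0.81 log units; beyond the scatter), so the pattern shared by the 2,6-difluorophenyl and 2,6-dichlorophenyl groups alone does not account for the weakness of compound 2. The 2,6-dichlorophenyl and 3-fluorophenyl groups cannot be told apart at this position, as the step lies within the scatter: a 1.3-fold higher number from compound 1 to compound 3 (0.11 log units; within the scatter). Compound 2 holds a limit and not a number, so the step to compound 3 has no fixed size: the limit of > 100000 nM in this assay, at which 1 of the 3 values shown sits.

The compounds shown leave open how an unsubstituted phenyl, a 2,6-dimethylphenyl or a 3-chlorophenyl group on this oxygen would read in this assay. Among the compounds shown here, they also leave open whether 2,6-difluorophenyl stands alone among such groups, since compound 1 and compound 3 offer only two other halogen-bearing phenyl groups for comparison.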